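Nitro in place of trifluoromethyl across two related cores

The source may hold more compounds than are shown below. What is called first, only, known or untested is meant among the compounds shown, and "the series" means these compounds.

Compound 1 `FC(F)(F)c1ccc(COc2ccccc2Nc2ncnc3cc4c(cc23)OCCOCCOCCO4)cc1` and compound 2 `FC(F)(F)c1ccc(COc2ccccc2Nc2ncnc3cc4c(cc23)OCCOCCO4)cc1` carry the same trifluoromethyl-bearing side chain on two different cores; the difference between the two cores is not broken down here. In a functional assay on DU-145 cells (Homo sapiens) for antiproliferative activity, read by MTT assay, with a stated time of 72 h (a higher number here means a weaker inhibitor, a lower number a stronger inhibitor), compound 1 gives only a limit, > 100000 nM. Compound 2 likewise gives only a limit in this assay, > 100000 nM. Compound 3 `O=[N+]([O-])c1ccc(COc2ccccc2Nc2ncnc3cc4c(cc23)OCCOCCO4)cc1` differs from compound 2 by nitro in place of trifluoromethyl on an aromatic carbon. In this assay compound 3 gives 85600 nM, a step of an at least 1.1-fold lower number from compound 2 to compound 3 (0.06 log units; that floor lies within the scatter). Compound 4 `O=[N+]([O-])c1ccc(COc2ccccc2Nc2ncnc3cc4c(cc23)OCCOCCOCCO4)cc1` differs from compound 1 by the same change, (nitro in place of trifluoromethyl on an aromatic carbon), here made on the core of compound 1. Compound 4 is expected to give about 100000 nM in this assay, within 60000 nM to 200000 nM. The expected step is a number no higher from compound 1 to compound 4 (the limit leaves the size open), resting on an at least 1.1-fold lower number from compound 2 to compound 3 (0.06 log units; that floor lies within the scatter) and on compound 1 sitting at the limit of > 100000 nM in this assay, at which 2 of the 3 values shown sit, so a reported limit rather than a number remains quite likely.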

Compound 4, half-maximal inhibitory concentration: > 100000 nM
Compound 4: no number, only a limit; the forecaster's own chance of this, stated with the estimate: 55%; the middle value sits exactly at the limit.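

Compound 4 gives only a limit in this assay, > 100000 nM. Among the compounds shown here, compound 1 is also only a limit, so no step between compound 1 and compound 4 can be read. Still open, on these data alone, is whether nitro in place of trifluoromethyl changes the number on the core of compound 1.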